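A fluoro step from compound 2, not yet measured

This account rests on a few compounds, and the source may have more. Where it says the series, first, only, none or still open, it means among the compounds named here.

Compound 1 `O=C(Nc1ccc2c(c1)B(O)OC2)c1ccccc1F`: > 10000 nM
Compound 2 `O=C(Nc1ccc2c(c1)B(O)OC2)c1cccc(C(F)(F)F)c1`: > 10000 nM

Both compounds have been examined in a functional assay on PBMC cells (Homo sapiens) for inhibition, read by HTRF, with stated times of 15 min and 24 h; on this read-out higher numbers stand for weaker inhibition and lower numbers for stronger inhibition. In this assay compound 1 gives > 10000 nM, which is a limit of the assay and not a number. In the same read-out compound 2 gives > 10000 nM, which is also a limit and not a number. Going by the values given here, the series so far therefore rests entirely on (the limit of > 10000 nM in this assay, at which 2 of the 2 values shown sit), and compound 2 has no measured number to be ranked by.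

Compound 3 `O=C(Nc1ccc2c(c1)B(O)OC2)c1cc(C(F)(F)F)ccc1F` has yet to be measured in this assay. Its difference from compound 2 is fluoro in place of hydrogen on an aromatic carbon, ortho to a large group and para to a trifluoromethyl group. Among the compounds with values here, no measured step shows what such a change does. The expectation therefore rests on compound 2, whose > 10000 nM is a limit. No change beyond the usual scatter is expected, and the estimated change is a number no higher from compound 2 to compound 3 (the limit leaves the size open). A report of only a limit is the likeliest outcome. For compound 3 the estimate is 10000 nM, with an expected range from 3000 nM to 30000 nM.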

Compound 3, half-maximal inhibitory concentration: > 100000 nM
Compound 3 was reported as a limit; the forecaster's own chance of this, stated with the estimate: 70%; middle value at least 10-fold (1.00 log units) from the limit.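

In this assay compound 3 gives > 100000 nM, which is a limit and not a number. Going by these compounds alone, with compound 1 and compound 2 also reported only as limits, no step to compound 3 from either can be read. The compounds shown leave open whether either of these two single changes alters inhibition at all in this assay.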